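This account rests on a few compounds, and the source may have more. Where it says the series, first, only, none or still open, it means among the compounds named here.

Measured so far:
- Compound 1 `O=C1C(Nc2cccc(Cl)c2)=CC(=O)c2c1nc1n2[C@H]2OC[C@@H](O)[C@H]2OC1`: 7970 nM
- Compound 2 `O=C1C=C(Nc2ccc(C(F)(F)F)cc2)C(=O)c2c1nc1n2[C@H]2OC[C@@H](O)[C@H]2OC1`: > 8000 nM

The two compounds share a core and differ only in the group on the aniline ring. Among the compounds with values here, in a functional assay on HeLa cells (Homo sapiens) for inhibition, read by sulforhodamine B assay (a lower number here means a stronger inhibitor, a higher number a weaker inhibitor), compound 1 gives 7970 nM, the only actual number among the results. Compound 2 gives > 8000 nM, which is a limit of the assay and not a number. Within the data shown here, compound 1 thus stands as the one compound with a measured value, and it sits close to the limit of > 8000 nM in this assay, at which 1 of the 2 values shown sits. Compound 3 `O=C1C(Nc2ccccc2)=CC(=O)c2c1nc1n2[C@H]2OC[C@@H](O)[C@H]2OC1` has not yet been measured; it differs from compound 1 by hydrogen in place of chloro on an aromatic carbon. Among the measured compounds shown here, no step between measured compounds is available, so the expectation rests on compound 1 alone. The step is expected to be a 1.4-fold higher number from compound 1 to compound 3 (0.14 log units; within the scatter), a modest shift toward weaker inhibition that may not exceed the usual scatter. Compound 3 is therefore estimated at 11000 nM, within a range from 4500 nM to 30000 nM, with a real chance that only a limit is reported.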

Compound 3, half-maximal inhibitory concentration: > 8000 nM
Compound 3: only a limit was reported; the forecaster's own chance of this, stated with the estimate: 55%; the middle value does not contradict the limit.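

In this assay, replacing the chloro group on the aniline ring, at its place meta to a large group, with hydrogen gives a number no lower from compound 1 to compound 3 (the limit leaves the size open). Compound 3 gives > 8000 nM, which is a limit of the assay and not a number. This is the first direct test of the chloro group at this position, yet it shows only the direction of the change, and its size cannot be read because the values gather at one limit: the limit of > 8000 nM in this assay, at which 2 of the 3 values shown sit.

Left open is whether any other group on this aromatic carbon, such as a methoxy group, an amine or a carboxylic acid, would give a clearly stronger inhibitor than compound 1. Also open, going by these compounds, is whether the chloro group would behave differently at another place on the aniline ring.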